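Replacing the aryl group of compound 2

The source may hold more compounds than are shown below. What is called first, only, known or untested is meant among the compounds shown, and "the series" means these compounds.

Compound 1 `O=C(CCCCCCNC(=O)C(O)(O)C(F)(F)F)Nc1ccccc1Br`: 14500 nM
Compound 2 `COc1ccccc1NC(=O)CCCCCCNC(=O)C(O)(O)C(F)(F)F`: 10100 nM

In a functional assay on HCT-116 cells (Homo sapiens) for inhibition, read by colorimetric assay, with a stated time of 3 days (on this read-out higher numbers stand for weaker inhibition and lower numbers for stronger inhibition), compound 2 gives 10100 nM, level with compound 1 once the scatter is allowed for. Going by the values given here, the only measured step is a 1.4-fold lower number from compound 1 to compound 2 (0.16 log units; within the scatter). Compound 3 `CC(=O)c1ccc(NC(=O)CCCCCCNC(=O)C(O)(O)C(F)(F)F)cc1` brings (4-acetylphenyl in place of 2-methoxyphenyl on an amide-type nitrogen), with 4-acetylphenyl in place of 2-methoxyphenyl on an amide-type nitrogen. Among the compounds with values here, no measured step involves a 4-acetylphenyl group, so that one small step is the sole guide, and no change beyond the scatter is expected. The expected step is a 1.1-fold lower number from compound 2 to compound 3 (0.05 log units; within the scatter). For compound 3 the estimated value is 9000 nM, with an expected range of 3500 nM to 22000 nM.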

Compound 3, half-maximal inhibitory concentration: 12100 nM
The estimate for compound 3 lay 1.3-fold (0.13 log units) below the measured number; measured number inside the range.
By their numbers in this assay, from the lowest: compounds 2, 3 and 1 (each within the scatter of the next).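

In this assay the 4-acetylphenyl group on the amide-type nitrogen gives a 1.2-fold higher number from compound 2 to compound 3 (0.08 log units; within the scatter) and a 1.2-fold lower number from compound 1 to compound 3 (0.08 log units; within the scatter) and so stands level with both 2-methoxyphenyl and 2-bromophenyl. The earlier pair covered only those last two groups; with a third aryl group at this place, the numbers still do not separate. Nothing available explains why these three groups stay level. From the compounds shown here alone, whether an amine or a carboxylic acid on the aromatic ring would move the number beyond the scatter remains open. So does the effect of a longer chain in the shared core.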